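Swapping a methoxy for an amino on a biaryl phenol

A few compounds are considered here, and "the series" means these few. Any claim that something is new, unique, unknown or untested is made for them only; others in the source may bear on it.

Measured compounds:
Compound 1 `COc1ccccc1-c1cccc(O)c1` — 50 ug/mL
Compound 2 `COc1cccc(-c2cccc(O)c2)c1` — 34 ug/mL

Two compounds share a core of two linked six-membered aromatic rings, one of them carrying a hydroxyl. In an ADME assay on HEK293 cells (Homo sapiens) for cytotoxicity, read by MTT assay, with a stated time of 3 days (a lower number here means a stronger inhibitor, a higher number a weaker inhibitor), compound 1 gives 50 ug/mL, and in this assay compound 2 gives 34 ug/mL. Compound 2 stands at one end of these two numbers, but compound 1 sits close by, and the gap between them lies within the usual scatter of repeated measurements, so the two cannot be told apart on this evidence.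

Compound 3 `Nc1cccc(-c2cccc(O)c2)c1` has not yet been measured. It differs from compound 2 in one place: amino in place of methoxy on an aromatic carbon. Going by the values given here, no measured pair shows what this particular exchange does, so the direction of the step is open. With only the two measured numbers to lean on, and both of them in the same region, the expectation is a step of modest size at most, and a value that may simply fall inside the scatter of compound 2.

The estimate for compound 3 in this assay is 35 ug/mL, with a range from 15 ug/mL to 80 ug/mL.

Expressed as a step, that estimate means a 1.0-fold higher number from compound 2 to compound 3 (0.01 log units; within the scatter).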

Compound 3, half-maximal inhibitory concentration: 50.1 ug/mL
Estimate against measurement, compound 3: 1.4-fold (0.16 log units) below, within the range that was stated.
By their numbers in this assay, from the lowest: compounds 2, 1 and 3 (each within the scatter of the next).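

In this assay, putting amino in place of methoxy on this aromatic carbon gives a 1.5-fold higher number from compound 2 to compound 3 (0.17 log units; within the scatter) and so leaves compound 2 and compound 3 indistinguishable. Going by these compounds alone, this pair is the first direct look at the exchange, and it shows that at this place, meta to a group of 7 heavy atoms, a methoxy with 2 heavy atoms and 0 hydrogen-bond donors can give way to an amino with 1 heavy atom and 1 hydrogen-bond donor without a difference that stands clear of the usual scatter of repeated measurements. No evidence is available that would explain this result.

The compounds shown leave open whether a different group on the same aromatic carbon, such as a carboxylic acid, a nitrile or a longer chain like butoxy, would give a step beyond the scatter. They also leave open whether the same amino for methoxy exchange would stay as quiet at the place the methoxy occupies in compound 1, since a single pair at a single place cannot establish a wider pattern.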